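The source may hold more compounds than are shown below. What is called first, only, known or untested is meant among the compounds shown, and "the series" means these compounds.

Measured compounds in an ADME assay on Vero cells (Chlorocebus sabaeus) for cytotoxicity, read by resazurin assay, with a stated time of 3 days; a higher number here means a weaker inhibitor, a lower number a stronger inhibitor:
Compound 1 `CCOCCOC(=O)Nc1cc2nc(C3CCCCC3)[nH]c2cc1N1CCCC1` gives > 100 ug/mL, which is a limit of the assay and not a number.
Compound 2 `COc1ccc(C(=O)Nc2cc3nc(C4CCCCC4)[nH]c3cc2N2CCCC2)cc1` gives > 100 ug/mL, also a limit.
Compound 3 `CCCCNC(=O)Nc1cc2nc(C3CCCCC3)[nH]c2cc1N1CCCC1` gives > 100 ug/mL, again a limit.

Compound 1 therefore stands at the limit of this assay, together with the two other measured compounds, as the limit of > 100 ug/mL in this assay, at which 3 of the 3 values shown sit, records. The steps among them, a step that the two limits leave unreadable from compound 1 to compound 2, a step that the two limits leave unreadable from compound 1 to compound 3 and a step that the two limits leave unreadable from compound 2 to compound 3, all change the group on the carbonyl carbon and none can be read in size, since both ends sit at the limit.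

Compound 4 `CCOCCOC(=O)Nc1cc2nc(C3CCCCC3)[nH]c2cc1N(C)C` differs from compound 1 by dimethylamino in place of pyrrolidin-1-yl on an aromatic carbon. Within the data shown here, no measured step touches this part of the shared core, so none bears directly on it; the three compounds in hand give only the picture that every variation so far stays at the limit.

Compound 4 is accordingly expected to remain at the limit as well, with an estimate of 100 ug/mL in this assay, between 50 ug/mL and 200 ug/mL. The step of a number no higher from compound 1 to compound 4 (the limit leaves the size open) is expected to show no change beyond the scatter.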

Compound 4, half-maximal inhibitory concentration: > 100 ug/mL
Compound 4 ended at the assay's limit; the forecaster's own chance of this, stated with the estimate: 85%; the middle value sits exactly at the limit.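

Compound 1 and compound 4 both sit at the limit in this assay, so the step between them, dimethylamino in place of pyrrolidin-1-yl, cannot be read in size. The compounds shown leave open how far any of the four lies beyond that limit in this assay and which change, if any, would bring a measurable value.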